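The source may report more compounds than this note shows. Statements on the series, on what has been measured and on what is new or still open speak of the compounds shown alone.

Measured in a functional assay for inhibition, with Rattus norvegicus as the target; on this read-out higher numbers stand for weaker inhibition and lower numbers for stronger inhibition:

- Compound 1 `C/N=c1\c(O)c(O)\c1=N/c1ccc(C#N)cc1`: > 30000 nM (a limit)
- Compound 2 `CCCCCCC/N=c1\c(O)c(O)\c1=N/c1ccc(C#N)cc1`: > 30000 nM (a limit)
- Compound 3 `C[C@@H](/N=c1\c(O)c(O)\c1=N/c1ccc(C#N)cc1)C1CCCCC1`: 2600 nM

Compound 3 is the only one of the three with an actual number. The other two readings are the limit of > 30000 nM in this assay, at which 2 of the 3 values shown sit. Compound 4 `C[C@H](/N=c1\c(O)c(O)\c1=N/c1ccc(C#N)cc1)C1CCCCC1` has not yet been measured, and its relation to compound 3 is simple: the two compounds have the same atoms and bonds and differ only in configuration as drawn: 1 of 3 stereo elements differ; a stereocentre at a saturated chain carbon is drawn R in compound 3 and S in compound 4.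

Three measured steps offer context, though none changes configuration alone. Lengthening the chain gave a step that the two limits leave unreadable from compound 1 to compound 2. Placing 1-cyclohexylethyl in the position of methyl gave an at least 11-fold lower number from compound 1 to compound 3 (1.06 log units; beyond the scatter), and placing it in the position of heptyl gave an at least 11-fold lower number from compound 2 to compound 3 (1.06 log units; beyond the scatter). These last two steps are large and show that the group on the double-bonded nitrogen can shift the read-out in this assay considerably. The stereocentre of compound 4 lies within that same group, so a step beyond the scatter is plausible, although the data do not fix its direction. Compound 3, at 2600 nM, is the lone measured number, and a move towards weaker inhibition, with a higher number, is the more likely outcome.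

The expected change is a 3.5-fold higher number from compound 3 to compound 4 (0.54 log units; beyond the scatter).

For compound 4 the estimated value is 9000 nM, with an expected range from 1500 nM to 30000 nM.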

Compound 4, half-maximal inhibitory concentration: > 30000 nM
Compound 4: a limit, no number (the forecaster's own chance of this, stated with the estimate: 35%); at least 3.3-fold (0.52 log units) between middle value and limit.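

In this assay, holding 1-cyclohexylethyl on the double-bonded nitrogen and inverting only the drawn stereocentre at the saturated chain carbon gave an at least 11-fold higher number from compound 3 to compound 4 (1.06 log units; beyond the scatter). The earlier compounds had shown that swapping the whole group could shift the read-out, but the gain of compound 3 over compounds 1 and 2 now goes with the R form alone and not with 1-cyclohexylethyl as such, because nothing else separates the two forms: the fact that compounds 3 and 4 differ only in the configuration as drawn. The S form leaves compound 4 with a limit and no number, in the same position as compounds 1 and 2: the limit of > 30000 nM in this assay, at which 3 of the 4 values shown sit.

On these data alone, the steps from compounds 1 and 2 to compound 4 cannot be read, as both ends of each are limits, and the full size of the step to compound 4 also stays open. The compounds shown do not tell whether the R form would keep its lead with a phenyl group or a cyclopentyl group in place of the cyclohexyl, or with a carboxylic acid in place of the nitrile.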